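Arylsulfonyl saturated amines: acetamidomethyl replacing isopropylsulfonylamino

The source may hold more compounds than are shown below. What is called first, only, known or untested is meant among the compounds shown, and "the series" means these compounds.

Measured compounds:
compound 1 `CC(C)S(=O)(=O)NC1CCCN(S(=O)(=O)c2ccc(F)cc2)C1` — 1 mg/kg
compound 2 `CC(=O)NC1CCN(S(=O)(=O)c2ccc(F)cc2)CC1` — 0.01 mg/kg
compound 3 `CCCN1CCN(S(=O)(=O)c2ccc(F)cc2)CC1` — 1 mg/kg

All three were read in a functional assay on the whole organism with Mus musculus as the target, with a stated time of 30 min; a lower number here means that less compound is needed, a higher number that more compound is needed for the effect. Compound 1 gives 1 mg/kg and compound 3 gives 1 mg/kg; the two are level within the scatter, and together they carry the highest numbers of the set. Compound 2, which carries an acetamido group on its saturated ring, gives 0.01 mg/kg, a far lower number than compound 1 and well beyond the scatter.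

Compound 4 `CC(=O)NCC1CCCN(S(=O)(=O)c2ccc(F)cc2)C1` has not yet been measured. Relative to compound 1 the change is acetamidomethyl in place of (isopropylsulfonyl)amino on a saturated ring carbon. Going by the values given here, no step between measured compounds isolates this exact change, so the expectation rests on what the three values show: the compound bearing an acetyl amide, compound 2, sits far below compound 1 in this assay, while compound 1 and compound 3 sit together at the top.

Compound 4 brings an acetyl amide onto the same kind of ring, so the expected step of a 10-fold lower number from compound 1 to compound 4 (1.00 log units; beyond the scatter) is toward a lower number and beyond the scatter. Compound 4 is estimated at 0.1 mg/kg, with a range from 0.01 mg/kg to 1 mg/kg.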

Compound 4, minimum effective dose: 10 mg/kg
The estimate for compound 4 lay 100-fold (2.00 log units) below the measured number, outside the stated range (above it).
By their numbers in this assay, from the lowest: compound 2; then compounds 1 and 3 (each within the scatter of the next); then compound 4.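

On the core of compound 1, this assay records a 10-fold higher number from compound 1 to compound 4 (1.00 log units; beyond the scatter) when acetamidomethyl takes the place of (isopropylsulfonyl)amino on a saturated ring carbon, two ring bonds from the ring nitrogen. Going by these compounds alone, this is the first step that isolates a change in one place, and it shows that the number at this position depends on the group carried there. It also shows that, on this core and at this ring carbon, acetamidomethyl goes with more compound being needed for the effect, not less, so an acetyl amide cannot be read as a general route to a lower number across the series. The data offer no independent measurement that accounts for this step.

The step changes the sulfonyl part to an acetyl part and adds a methylene spacer at the same time, so the share of each remains unresolved; (isopropylsulfonyl)aminomethyl at this ring carbon would separate the two. On these data alone, whether a plain aminomethyl or a longer chain such as propanamidomethyl at this position would move the number in either direction also remains open.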